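Piperidinyl for nitro on the cinnamamide aryl ring

The compounds below may be only part of what the source reports. "The series", "measured", "known", "first", "only" and "open" are said of these compounds alone.

Among the compounds with values here, compound 2 `Cc1cc(C)c(-c2csc(NC(=O)/C=C/c3ccc([N+](=O)[O-])cc3)n2)c(C)c1` has the highest number so far in a functional assay on K562 cells (Homo sapiens) for inhibition, read by MTT assay, with a stated time of 96 h (a higher number here means a weaker inhibitor, a lower number a stronger inhibitor), where compound 2 gives 32200 nM. Within the data shown here, the nearest measured neighbour is compound 1 `COc1ccc(/C=C/C(=O)Nc2nc(-c3c(C)cc(C)cc3C)cs2)cc1`, which in this assay gives 4160 nM; the only measured step, a 7.7-fold higher number from compound 1 to compound 2 (0.89 log units; beyond the scatter), separates the two and is beyond the scatter.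

Compound 3 `Cc1cc(C)c(-c2csc(NC(=O)/C=C/c3ccc(N4CCCCC4)cc3)n2)c(C)c1` is the next member, not yet measured in this assay. The change from compound 2 is piperidin-1-yl in place of nitro on an aromatic carbon. Among the measured compounds shown here, no measured step involves a piperidin-1-yl group, so the step from compound 1 to compound 2 is the only guide: replacing the methoxy group by nitro at the same position raised the number, and the present change removes that nitro again in favour of a ring substituent carrying one hydrogen-bond acceptor, as does the methoxy of compound 1. The expectation is therefore a lower number, of a size comparable to the earlier step, because compound 1 gives 4160 nM with an oxygen-bearing group at that carbon.

Compound 3 is expected to give 5000 nM in this assay, estimated range 1500 nM to 20000 nM. The expected step is a 6.4-fold lower number from compound 2 to compound 3 (0.81 log units; beyond the scatter).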

Compound 3, half-maximal inhibitory concentration: 4060 nM
Beside the measured number, compound 3's estimate is 1.2-fold (0.09 log units) above it; low and high end bracket the measured number.
By their numbers in this assay, from the lowest: compounds 3 and 1 (each within the scatter of the next); then compound 2.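

At the aromatic carbon para to a large group, this assay shows that nitro can be replaced by a nitrogen-linked ring with a 7.9-fold lower number from compound 2 to compound 3 (0.90 log units; beyond the scatter) and that this is not limited to a return to methoxy, so among these three compounds compound 2 is the one that stands apart. Methoxy and piperidin-1-yl cannot be separated at this carbon, with a 1.0-fold lower number from compound 1 to compound 3 (0.01 log units; within the scatter) in spite of the six heavy atoms and the six-membered non-aromatic ring that piperidin-1-yl brings, so the added ring carries no measurable penalty in this assay. Nothing available here accounts for the difference between nitro and the other two groups.

The three compounds leave open whether any group at this carbon can take the number clearly lower than methoxy and piperidin-1-yl do, which a simple amine such as dimethylamino, a morpholin-4-yl ring or a carboxylic acid would begin to test. They also leave open whether the nitro result is particular to nitro or is shared by other groups such as nitrile or trifluoromethyl.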